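Nitro to Methoxy: A Small Change on a Shared Core

The source may report more compounds than this note shows. Statements on the series, on what has been measured and on what is new or still open speak of the compounds shown alone.

Compound 1 `Cc1ccccc1-c1nnc(-n2[se]c3ccccc3c2=O)s1`: 36800 nM
Compound 2 `O=c1c2ccccc2[se]n1-c1nnc(-c2ccccc2[N+](=O)[O-])s1`: 31200 nM

Both compounds were tested in a functional assay on MCF7 cells (Homo sapiens) for antiproliferative activity, read by CCK-8 assay, with a stated time of 48 h; on this read-out lower numbers stand for stronger inhibition and higher numbers for weaker inhibition. Compound 2 gives the lowest of the two numbers, yet the step of a 1.2-fold lower number from compound 1 to compound 2 (0.07 log units; within the scatter) is too small to separate the pair; the two results look alike. Compound 3 `COc1ccccc1-c1nnc(-n2[se]c3ccccc3c2=O)s1` has not yet been measured. It differs from compound 2 by methoxy in place of nitro on an aromatic carbon. Within the data shown here, only one measured step speaks to this kind of change, the swap of methyl for nitro at the same position, and that step a 1.2-fold lower number from compound 1 to compound 2 (0.07 log units; within the scatter) stayed within the scatter. Exchanging a small group at this spot has so far left this assay unmoved, so no step beyond the scatter is expected for methoxy either, in no particular direction. Compound 3 is therefore estimated at 33000 nM, within a range of 15000 nM to 75000 nM, which means an expected step of a 1.1-fold higher number from compound 2 to compound 3 (0.02 log units; within the scatter).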

Compound 3, half-maximal inhibitory concentration: 3920 nM
Compound 3: the middle estimate sits 8.4-fold (0.93 log units) above what was measured; the measured number lies below the stated range.
By their numbers in this assay, from the lowest: compound 3; then compounds 2 and 1 (each within the scatter of the next).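

This position is not indifferent to what sits on it in this assay: methoxy in place of nitro gives a modest step beyond the scatter (an 8.0-fold lower number from compound 2 to compound 3 (0.90 log units; beyond the scatter)), and methoxy in place of methyl gives one of similar size (a 9.4-fold lower number from compound 1 to compound 3 (0.97 log units; beyond the scatter)). Methyl and nitro, whose results lie within the scatter of each other, therefore do not speak for every small group here, and among these three compounds only the methoxy compound stands apart. Nothing measured here explains why methoxy behaves differently from the other two groups.

Going by these compounds, it remains open whether a longer chain such as ethoxy, or a small group such as an amine or a hydroxyl, on this same carbon would match methoxy. Also open, on these data alone, is whether methoxy would give a similar step elsewhere on this ring.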